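Swapping a phenyl for an amine-bearing chain on a pyrazoline amide

This account rests on a few compounds, and the source may have more. Where it says the series, first, only, none or still open, it means among the compounds named here.

Measured compounds:
- compound 1, `CC1=NN(C(=O)CN2CCCCC2)C(c2ccccc2O)C1`: 3020 nM
- compound 2, `CC(=O)Oc1ccccc1C1CC(C)=NN1C(=O)CCl`: 2520 nM
- compound 3, `O=C(c1ccccc1)N1N=C(c2cc3ccccc3oc2=O)CC1c1ccccc1`: 36600 nM

Of the compounds shown here, three have been tested in a functional assay on HepG2 cells (Homo sapiens) for cytotoxicity, read by MTT assay, with a stated time of 48 h; a lower number here means a stronger inhibitor, a higher number a weaker inhibitor. Compound 1 gives 3020 nM and compound 2 gives 2520 nM, while compound 3 gives 36600 nM. Compound 3 thus stands highest of the three numbers; its gap to compound 1 and its gap to compound 2 both lie beyond the usual scatter, so compound 3 is the weakest inhibitor of the set.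

The next compound, compound 4, `CC(C)(C)NCC(=O)N1N=C(c2cc3ccccc3oc2=O)CC1c1ccccc1`, keeps the core of compound 3 and alters only the group on the carbonyl carbon attached to the ring nitrogen: ((tert-butyl)amino)methyl in place of phenyl on a carbonyl carbon. Going by the values given here, no measured pair in this set shows this exact change, so its effect can only be guessed from what the three numbers show. Compound 1 also carries an amine-bearing chain on the carbonyl attached to its ring nitrogen and gives 3020 nM, well below compound 3. A move toward a lower number is therefore the expectation, though the rest of compound 4 stays as in compound 3. Compound 4 is estimated at 12000 nM, within 4000 nM to 36000 nM, meaning an expected step of a 3.1-fold lower number from compound 3 to compound 4 (0.48 log units; beyond the scatter).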

Compound 4, half-maximal inhibitory concentration: 31400 nM
Compound 4: the middle estimate sits 2.6-fold (0.42 log units) below what was measured, within the range that was stated.
By their numbers in this assay, from the lowest: compounds 2 and 1 (each within the scatter of the next); then compounds 4 and 3 (each within the scatter of the next).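

In this assay, the step of a 1.2-fold lower number from compound 3 to compound 4 (0.07 log units; within the scatter) shows that, on this shared core, a carbonyl carbon bonded to an amide-type nitrogen in a ring can carry either phenyl or ((tert-butyl)amino)methyl with no difference that rises above the scatter. The swap removes an aromatic ring of carbon only and brings in an open chain with a hydrogen-bond donor and a hydrogen-bond acceptor, yet on this core that single change does not give a lower number. Nothing measured here explains why the two groups read alike.

From the compounds shown here alone, whether a morpholine-bearing methyl, a carboxylic acid or a longer amine chain in place of ((tert-butyl)amino)methyl would shift the number on this core remains open. Also open, going by these compounds, is whether the same swap would behave in the same way on the core of compound 1, which differs from compound 4 in more than one place and so cannot be compared with it directly.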